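Methylating one hydroxyl of the catechol hydrazone

The source may report more compounds than this note shows. Statements on the series, on what has been measured and on what is new or still open speak of the compounds shown alone.

Compound 1 `CN(C)CCn1cnnc1-c1cc(Oc2ccc(NC(=O)N/N=C/c3ccc(O)c(O)c3)cc2F)ccn1` carries a 3,4-dihydroxyphenyl on the carbon with a double bond to nitrogen. In a functional assay on U-87MG ATCC cells (Homo sapiens) for cytotoxicity, read by MTT assay, with a stated time of 72 h (a lower number here means a stronger inhibitor, a higher number a weaker inhibitor), compound 1 gives only a limit of the assay, > 100000 nM. Compound 3 `CN(C)CCn1cnnc1-c1cc(Oc2ccc(NC(=O)N/N=C/c3c(Cl)cccc3Cl)cc2F)ccn1` likewise gives only a limit, > 100000 nM. Among the compounds with values here, compound 2 `Cc1cc(/C=N/NC(=O)Nc2ccc(Oc3ccnc(-c4nncn4CCN(C)C)c3)c(F)c2)cc(C)c1O` is the one member with a number, giving 7710 nM in this assay. The step of an at least 12-fold lower number from compound 1 to compound 2 (1.11 log units; beyond the scatter) is the only readable move within the series, while an at least 12-fold higher number from compound 2 to compound 3 (1.11 log units; beyond the scatter) returns to the ceiling; the step from compound 1 to compound 3 is unreadable because the limit of > 100000 nM in this assay, at which 2 of the 3 values shown sit, covers both ends. Compound 4 `COc1cc(/C=N/NC(=O)Nc2ccc(Oc3ccnc(-c4nncn4CCN(C)C)c3)c(F)c2)ccc1O` differs from compound 1 by methyl in place of hydrogen on an oxygen on an aromatic ring. Within the data shown here, no measured step changes a hydroxyl to a methoxy, so nothing bears directly on this move; compound 2 shows only that a 4-hydroxyphenyl flanked by substituents can bring a number below the ceiling. Compound 4 is therefore expected to land somewhere between the limit of compound 1 and the value of compound 2, an estimated 30000 nM with a range of 6000 nM to 100000 nM. The expected step is an at least 3.3-fold lower number from compound 1 to compound 4 (0.52 log units; beyond the scatter), with a substantial chance that compound 4 again reports only a limit.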

Compound 4, half-maximal inhibitory concentration: > 100000 nM
Compound 4 gave a limit, no number; the forecaster's own chance of this, stated with the estimate: 45%; at least 3.3-fold (0.52 log units) between middle value and limit.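

The hydroxy-to-methoxy change on the 3,4-dihydroxyphenyl, which gives the 4-hydroxy-3-methoxyphenyl, does not bring a number into this assay: compound 4 gives > 100000 nM, and this is a limit of the assay. With a 4-hydroxy group on the aryl ring in three of the four compounds, only the 4-hydroxy-3,5-dimethylphenyl gives a number, and replacing it with 4-hydroxy-3-methoxyphenyl produces an at least 12-fold higher number from compound 2 to compound 4 (1.11 log units; beyond the scatter); among the compounds shown, the 4-hydroxy group alone therefore does not go with a number, as compound 1 and compound 4 both carry it and sit at the limit. The two steps into compound 4 from compound 1 and compound 3 cannot be read because both ends of each sit at the same limit: the limit of > 100000 nM in this assay, at which 3 of the 4 values shown sit.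

Any effect of the methyl on the oxygen remains hidden at this limit, so a shift in the true values cannot be ruled in or out. A 4-hydroxy-3-methylphenyl would show whether one methyl group suffices for a number, while a 4-amino-3,5-dimethylphenyl would show whether the hydroxyl of compound 2 can be replaced by an amine.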